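A few compounds are considered here, and "the series" means these few. Any claim that something is new, unique, unknown or untested is made for them only; others in the source may bear on it.

Of the compounds shown here, three with a shared core have been tested in a functional assay on HeLa cells (Homo sapiens) for cytotoxicity, read by MTT assay, with a stated time of 2 days; on this read-out higher numbers stand for weaker inhibition and lower numbers for stronger inhibition. Among the compounds with values here, compound 1 `Cc1ccc2nc(-c3ccccc3N(C)C)[nH]c(=O)c2c1` gives 14000 nM, the only true number among them. Compound 2 `Cc1cccc(-c2nc3ccc(C)cc3c(=O)[nH]2)c1` reads > 50000 nM, and this is a limit of the assay and not a number. Compound 3 `Cc1ccc2c(=O)[nH]c(-c3cccc4ccccc34)nc2c1` reads > 50000 nM, which is likewise a limit. On these data alone, compound 2 therefore stands at the limit of > 50000 nM in this assay, at which 2 of the 3 values shown sit, so its real potency in this assay remains unknown.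

The next compound to be considered is compound 4 `Cc1ccc2nc(-c3cccc(OC(F)(F)F)c3)[nH]c(=O)c2c1`. It keeps the framework of compound 2 but carries trifluoromethoxy in place of methyl on an aromatic carbon, meta to a large group: trifluoromethoxy in place of methyl on an aromatic carbon. No measured pair among these compounds shows what such a change does in this assay, so the expectation has little to rest on. It starts from compound 2 at > 50000 nM, a limit, and assumes that this single substitution changes little. The estimated step, an at least 1.2-fold lower number from compound 2 to compound 4 (0.09 log units; that floor lies within the scatter), is expected to stay within the usual scatter, with no clear direction. A reading at the same limit would be no surprise. For compound 4 the expected value is 40000 nM, with an estimated range from 14000 nM to 80000 nM.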

Compound 4, half-maximal inhibitory concentration: > 50000 nM
Compound 4: only a limit was reported; the forecaster's own chance of this, stated with the estimate: 60%; middle value at least 1.2-fold (0.09 log units) from the limit.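

Within the data shown here, compound 2 and compound 4 both read as limits of the assay and not as numbers in this assay, so no step between them can be read: the limit of > 50000 nM in this assay, at which 3 of the 4 values shown sit. The compounds shown leave open whether trifluoromethoxy in place of methyl on an aromatic carbon changes potency at all, and the real potency of compound 2 and compound 4 remains unknown.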